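Substituting the Para Aryl Group: Methoxy to Nitro

The source may report more compounds than this note shows. Statements on the series, on what has been measured and on what is new or still open speak of the compounds shown alone.

Measured in an ADME assay on MDCK cells (Canis lupus familiaris) for cytotoxicity; a higher number here means that more compound is tolerated, a lower number that less compound is tolerated
- compound 1 `CC(=O)Nc1ccc2oc(-c3ccnc(C(=O)N4CCN(C(c5nnn(C)n5)c5ccccc5F)CC4)c3)nc2c1` gives > 50000 nM (a limit)
- compound 2 `CC(=O)Nc1ccc2oc(-c3ccnc(C(=O)N4CCN(C(c5ccc(Cl)cc5)c5nnn(C)n5)CC4)c3)nc2c1` gives > 50000 nM (a limit)
- compound 3 `COc1ccc(C(c2nnn(C)n2)N2CCN(C(=O)c3cc(-c4nc5cc(NC(C)=O)ccc5o4)ccn3)CC2)cc1` gives > 50000 nM (a limit)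

Among the measured compounds shown here, compound 3 has no number of its own, and all three compounds share one ceiling: the limit of > 50000 nM in this assay, at which 3 of the 3 values shown sit (no compound ranks above another). Compound 4 `CC(=O)Nc1ccc2oc(-c3ccnc(C(=O)N4CCN(C(c5ccc([N+](=O)[O-])cc5)c5nnn(C)n5)CC4)c3)nc2c1` carries nitro in place of methoxy on an aromatic carbon and is otherwise unchanged. The closest measured swaps are a step that the two limits leave unreadable from compound 2 to compound 3 and a step that the two limits leave unreadable from compound 1 to compound 3 (with a step that the two limits leave unreadable from compound 1 to compound 2 as a third). None of them gives a size, so no step beyond the scatter is expected in this assay here. The expected change is a number no higher from compound 3 to compound 4 (the limit leaves the size open) (an estimate only). For compound 4 the estimated value is 50000 nM (range 20000 nM to 100000 nM) and a limit is the likeliest report.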

Compound 4, half-maximal cytotoxic concentration: > 50000 nM
Compound 4 was reported as a limit; the forecaster's own chance of this, stated with the estimate: 85%; the middle value sits exactly at the limit.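

Among the compounds shown here, no step from compound 1, compound 2 or compound 3 to compound 4 can be read, because all four compounds sit at one shared limit: the limit of > 50000 nM in this assay, at which 4 of the 4 values shown sit.

The compounds shown leave open how far apart they truly lie in this assay, and at what concentration any of them would harm the cells.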